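Adding a Chloro Group to Compound 1: An Expectation

The source may hold more compounds than are shown below. What is called first, only, known or untested is meant among the compounds shown, and "the series" means these compounds.

Compound 1 `Cn1cc(-c2n[nH]c3ccc(Br)cc23)cn1` is the weaker of the two compounds measured in an assay on isolated protein for inhibition of tyrosine-protein kinase receptor UFO (Homo sapiens), with a stated time of 1.5 h (a higher number here means a weaker inhibitor, a lower number a stronger inhibitor), where compound 1 gives 1540 nM. Among the compounds with values here, its only measured neighbour is compound 2 `Cn1cc(-c2n[nH]c3ccc(-c4ccccc4)cc23)cn1`, which in this assay gives 620 nM; the change was a 2.5-fold lower number from compound 1 to compound 2 (0.40 log units; beyond the scatter). Compound 3 `Cn1cc(-c2n[nH]c3cc(Cl)c(Br)cc23)cn1` is not yet measured. It differs from compound 1 by chloro in place of hydrogen on an aromatic carbon. Within the data shown here, no measured step bears directly on this change: the single step from compound 1 to compound 2 replaces the bromo group itself rather than adding a group at another position, so it offers no guide to what a chloro added to the same ring will do. Without such a precedent, the expected outcome for compound 3 is a step of a 1.2-fold lower number from compound 1 to compound 3 (0.07 log units; within the scatter), not beyond the scatter. The estimate for compound 3 in this assay is 1300 nM, with a range from 500 nM to 3500 nM.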

Compound 3, half-maximal inhibitory concentration: 850 nM
Beside the measured number, compound 3's estimate is 1.5-fold (0.18 log units) above it, within the range that was stated.
By their numbers in this assay, from the lowest: compounds 2, 3 and 1 (each within the scatter of the next, the first and the last beyond it).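

The aromatic carbon ortho to a bromo group, meta to a fused ring and para to a fused ring is a second place on the shared core where a change can be read, and in this assay chloro in place of hydrogen there gives a 1.8-fold lower number from compound 1 to compound 3 (0.26 log units; within the scatter). The earlier compounds shown here spoke only to the bromo group itself, through a 2.5-fold lower number from compound 1 to compound 2 (0.40 log units; beyond the scatter), whereas this result shows that a chloro can stand on this carbon without a step beyond the scatter. Nothing shown here accounts for this result.

Going by these compounds, it remains open whether a different group on the same carbon, such as a methoxy group or an amine, would give a step beyond the scatter. Also open, on these data alone, is what the chloro does when phenyl stands in place of bromo, as in compound 2.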